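Replacing cyclohexylamino in compound 1 with a new amino group

The source may report more compounds than this note shows. Statements on the series, on what has been measured and on what is new or still open speak of the compounds shown alone.

Compound 1 `Cc1ccc(NC(=O)Nc2cc(-c3ccccc3C(=O)O)ccc2NC2CCCCC2)cc1` is the weakest of the three compounds measured in an assay on HeLa cells for inhibition of Indoleamine 2,3-dioxygenase 1 (Homo sapiens), with stated times of 1 h and 18 h (a lower number here means a stronger inhibitor, a higher number a weaker inhibitor), where compound 1 gives 504 nM. Compound 2 `CCN(c1ccc(-c2ccccc2C(=O)O)cc1NC(=O)Nc1ccc(C)cc1)C1CCCC1` gives 23 nM, and compound 3 `Cc1ccc(NC(=O)Nc2cc(-c3ccccc3C(=O)O)ccc2N2CCC[C@@H]3CCCC[C@@H]32)cc1` gives 159 nM. Compound 4 `Cc1ccc(NC(=O)Nc2cc(-c3ccccc3C(=O)O)ccc2N(CC2CC2)CC2CC2)cc1` differs from compound 1 in one place: bis(cyclopropylmethyl)amino in place of cyclohexylamino on an aromatic carbon. Two measured steps start from the same cyclohexylamino group of compound 1. a 22-fold lower number from compound 1 to compound 2 (1.34 log units; beyond the scatter) was a large gain, and a 3.2-fold lower number from compound 1 to compound 3 (0.50 log units; beyond the scatter) a modest one. Both changes at this position lowered the number, and compound 2 is the nearer analogy, so a clear decrease is expected for compound 4, though its size is uncertain. Compound 4 is estimated at 50 nM, within 15 nM to 180 nM, an expected step of a 10-fold lower number from compound 1 to compound 4 (1.00 log units; beyond the scatter).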

Compound 4, half-maximal inhibitory concentration: 348 nM
The estimate for compound 4 lay 7.0-fold (0.84 log units) below the measured number, and the stated range ends below it.
By their numbers in this assay, from the lowest: compound 2; then compound 3; then compounds 4 and 1 (each within the scatter of the next).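

Exchanging cyclohexylamino for bis(cyclopropylmethyl)amino, which has 0 hydrogen-bond donors, gives a 1.4-fold lower number from compound 1 to compound 4 (0.16 log units; within the scatter), so this larger group brings no real change. Not every substituted amino group here gives a clear gain: bis(cyclopropylmethyl)amino falls well short of cyclopentyl(ethyl)amino, with a 15-fold higher number from compound 2 to compound 4 (1.18 log units; beyond the scatter), and also short of the group in compound 3, with a 2.2-fold higher number from compound 3 to compound 4 (0.34 log units; beyond the scatter). No measurement shown explains these differences. Going by these compounds, whether the ethyl or the cyclopentyl part of compound 2 matters more remains open; cyclohexyl(ethyl)amino and diethylamino would help separate the two.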